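Chloro to tert-butyl in a small amide series

The source may report more compounds than this note shows. Statements on the series, on what has been measured and on what is new or still open speak of the compounds shown alone.

In an ADME assay on HEp-2 cells (Homo sapiens) for cytotoxicity (a higher number here means that more compound is tolerated, a lower number that less compound is tolerated), three amides built on one shared core have been measured. Compound 1 `O=C(Nc1ccccc1)[C@@H]1CCCN1S(=O)(=O)c1cccc2cccnc12` gives 35600 nM. Compound 2 `Cc1ccnc(C)c1NC(=O)[C@@H]1CCCN1S(=O)(=O)c1cccc2cccnc12` gives > 50000 nM, which is a limit of the assay and not a number. Compound 3 `Cc1ccc(Cl)cc1NC(=O)[C@@H]1CCCN1S(=O)(=O)c1cccc2cccnc12` gives 10000 nM, the lowest of the values shown.

Compound 4 `Cc1ccc(C(C)(C)C)cc1NC(=O)[C@@H]1CCCN1S(=O)(=O)c1cccc2cccnc12` differs from compound 3 in a single group, with tert-butyl in place of chloro on an aromatic carbon.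

Going by the values given here, two measured steps bear on this part of the molecule. They are a 3.6-fold lower number from compound 1 to compound 3 (0.55 log units; beyond the scatter) and an at least 5.0-fold lower number from compound 2 to compound 3 (0.69 log units; beyond the scatter). Both bring in the 5-chloro-2-methylphenyl group on the amide-type nitrogen, so they show that changing this group can move the number beyond the scatter. Among the compounds with values here, neither separates the chloro from the methyl, however, and no measured step changes the chloro alone.

With compound 3 at 10000 nM and no direct guide to this swap, a step beyond the scatter is not expected. The expected result is a 1.3-fold lower number from compound 3 to compound 4 (0.10 log units; within the scatter). For compound 4 the estimate is 8000 nM, with an expected range from 2500 nM to 30000 nM.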

Compound 4, half-maximal cytotoxic concentration: 6500 nM
The estimate for compound 4 lay 1.2-fold (0.09 log units) above the measured number; measured number inside the range.
By their numbers in this assay, from the lowest: compounds 4 and 3 (each within the scatter of the next); then compound 1. At a limit, above all of these: compound 2.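

In this assay, the swap at this ring carbon, para to a methyl group and meta to a large group, gives a 1.5-fold lower number from compound 3 to compound 4 (0.19 log units; within the scatter), so a chloro of 1 heavy atom can give way to a tert-butyl of 4 heavy atoms without a change that can be told from the scatter. Going by these compounds alone, this is the first measured step that alters this one group alone, whereas the earlier steps each exchanged the whole group on the amide-type nitrogen and so could not separate the chloro from the methyl. The compounds shown offer nothing that explains why the two groups cannot be told apart here.

Still open, on these data alone, is whether a plain hydrogen, an amine or a carboxylic acid at this carbon would also stay within the scatter of compound 3, or whether removing the methyl group would account for the earlier steps. The top of the series is also unresolved, since the value of compound 2 is a limit of the assay and not a number: the limit of > 50000 nM in this assay, at which 1 of the 4 values shown sits.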